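Thioester to Ketone on a Dienyl Chain

The source may hold more compounds than are shown below. What is called first, only, known or untested is meant among the compounds shown, and "the series" means these compounds.

The measured compounds:
compound 1 `CSC(=O)/C=C(C)/C=C/CC(C)CCCC(C)C`, 7.44
compound 2 `C#CCSC(=O)/C=C(C)/C=C/CC(C)CCCC(C)C`, 5.07
compound 3 `COC(C)(C)CCCC(C)C/C=C/C(C)=C/C(=O)SC`, 6.24

In a physicochemical assay for lipophilicity (on this read-out lower numbers stand for lower lipophilicity and higher numbers for higher lipophilicity), compound 3 stands second highest of the three, with compound 2 nearer and compound 1 further off. The two known steps, a number 2.37 log units lower from compound 1 to compound 2 (beyond the scatter) and a number 1.20 log units lower from compound 1 to compound 3 (beyond the scatter), both add a group to the chain and neither touches the carbonyl, so they do not bear directly on the change to compound 4 `CCC(C)C(=O)/C=C(C)/C=C/CC(C)CCCC(C)(C)OC`: sec-butyl in place of methylsulfanyl on a carbonyl carbon. Going by the values given here, with no step of this kind among the measured compounds, the account can only expect that swapping a sulfur-bearing group for a four-carbon one raises the value by a modest amount, a number 0.76 log units higher from compound 3 to compound 4 (beyond the scatter). Compound 4 is estimated at 7, within 6 to 8.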

Compound 4, partition coefficient: 6.02
Beside the measured number, compound 4's estimate is 0.98 log units above it; the measured number falls inside the stated range.
By their numbers in this assay, from the lowest: compound 2; then compounds 4 and 3 (each within the scatter of the next); then compound 1.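

In this assay, sec-butyl in place of methylsulfanyl on a carbonyl carbon gives a number 0.22 log units lower from compound 3 to compound 4 (within the scatter). This is the only step shown at this position, and unlike a number 2.37 log units lower from compound 1 to compound 2 (beyond the scatter) and a number 1.20 log units lower from compound 1 to compound 3 (beyond the scatter), it does not go beyond the scatter. No measured evidence accounts for this result.

On these data alone, it remains open whether an amine or a cyclohexyl group on this carbonyl carbon would also stay within the scatter of compound 3. Also open, as far as these compounds go, is whether the same exchange would read alike on compound 1, which has no methoxy.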